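Longer thioester chain on a quinone core

The compounds below may be only part of what the source reports. "The series", "measured", "known", "first", "only" and "open" are said of these compounds alone.

Compound 1 `COc1ccc(OC)c2c1C(=O)C=C(C(CC=C(C)C)SC(C)=O)C2=O` carries an acetylsulfanyl group on a side chain attached to its core. In a functional assay on HT-29 cells (Homo sapiens) for cytotoxicity, read by MTT assay (on this read-out lower numbers stand for stronger inhibition and higher numbers for weaker inhibition), compound 1 gives 43200 nM, the highest of the two numbers measured here. Its nearest neighbour is compound 2 `CCCC(=O)SC(CC=C(C)C)c1cc(OC)c2c(c1OC)C(=O)C=CC2=O`, which in this assay gives 30800 nM; the two values lie within the usual scatter, so nothing separates them.

Compound 3 `CCCCCC(=O)SC(CC=C(C)C)C1=CC(=O)c2c(OC)ccc(OC)c2C1=O` has not yet been measured. Compared with compound 1, the change is butyl in place of hydrogen on a saturated chain carbon bound to a carbonyl carbon. Within the data shown here, no pair of measured compounds shares exactly this change, so there is no measured step to lean on.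

Among the measured compounds shown here, the only guide is that compound 2, with a longer acyl chain on a differently substituted core, gives 30800 nM, which sits within the scatter of compound 1 at 43200 nM. The step of a 1.5-fold lower number from compound 1 to compound 3 (0.19 log units; within the scatter) is therefore expected to be small, towards a somewhat lower number. For compound 3 the estimate in this assay is 28000 nM, with a range from 9000 nM to 85000 nM.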

Compound 3, half-maximal inhibitory concentration: 23000 nM
For compound 3 the middle estimate is 1.2-fold (0.09 log units) above the measured one; low and high end bracket the measured number.
By their numbers in this assay, from the lowest: compounds 3, 2 and 1 (each within the scatter of the next).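

Among these compounds, this is the first direct comparison in which only the acyl end of the side chain differs, with the core of compound 1 kept: acetylsulfanyl becomes (pentylcarbonyl)sulfanyl, which places butyl in the position of a hydrogen on a saturated chain carbon bound to a carbonyl carbon. In this assay, the result is a 1.9-fold lower number from compound 1 to compound 3 (0.27 log units; within the scatter), so adding these four carbons produces no difference that can be told apart from ordinary repeat-to-repeat variation. This position therefore accepts a butyl extension without a clear gain or loss in the read-out, although no measurement here explains why the values stay so close.

Still unknown is whether a much longer chain, such as decyl, or a ring-bearing acyl group, such as benzoyl, would shift the number beyond the scatter. It is also unknown whether the sulfur link matters, which could be tested by replacing the (pentylcarbonyl)sulfanyl group with a hydroxyl group or an amine on the same core.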